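The compounds below may be only part of what the source reports. "The series", "measured", "known", "first", "only" and "open" are said of these compounds alone.

Series notes. The shared core carries a variable aryl group on a saturated chain carbon bound to an aromatic carbon. Compound 1 `Cc1cc(Cc2cccc(Br)c2)c(=O)n(CC(=O)Nc2ccc(Br)cc2)n1` bears 3-bromophenyl there. In an assay on HL-60 cells for agonist activity at N-formyl peptide receptor 3 (Homo sapiens), read by calcium flux (a higher number here means that more compound is needed for the effect, a lower number that less compound is needed), compound 1 gives only a limit of the assay, > 50000 nM. Compound 2 `Cc1cc(Cc2ccsc2)c(=O)n(CC(=O)Nc2ccc(Br)cc2)n1` carries thiophen-3-yl in the same place. In this assay compound 2 likewise returns a limit, > 50000 nM. Compound 3 `Cc1cc(Cc2cccnc2)c(=O)n(CC(=O)Nc2ccc(Br)cc2)n1` carries pyridin-3-yl there. In this assay compound 3 also stands at a limit, > 50000 nM. Every pairwise step among the three is therefore unreadable: a step that the two limits leave unreadable from compound 1 to compound 2, a step that the two limits leave unreadable from compound 1 to compound 3 and a step that the two limits leave unreadable from compound 2 to compound 3. Going by the values given here, the only evidence is the limit of > 50000 nM in this assay, at which 3 of the 3 values shown sit, so no direction for any aryl exchange on this carbon can be read from these numbers.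

Compound 4 `Cc1cc(Cc2ccc(C(N)=O)cc2)c(=O)n(CC(=O)Nc2ccc(Br)cc2)n1` has not been measured. The change from compound 3 is 4-carbamoylphenyl in place of pyridin-3-yl on a saturated chain carbon bound to an aromatic carbon. Among the compounds with values here, none of the measured steps bears on this exchange beyond showing that three different aryl groups on the saturated chain carbon bound to an aromatic carbon all leave the series at the limit. The expectation for compound 4 in this assay is therefore another limit rather than a number. Should a number appear, compound 4 is estimated at 50000 nM, between 15000 nM and 200000 nM. The step expected from compound 3 to compound 4 is accordingly a number no higher from compound 3 to compound 4 (the limit leaves the size open), no readable change.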

Compound 4, half-maximal effective concentration: > 50000 nM
Compound 4: no number, only a limit; the forecaster's own chance of this, stated with the estimate: 85%; the middle value lies on the limit itself.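

In this assay compound 4 returns only a limit, > 50000 nM. The steps joining compound 4 to compound 1, compound 2 and compound 3 therefore cannot be read, and the series stays at: the limit of > 50000 nM in this assay, at which 4 of the 4 values shown sit.

The compounds shown leave open whether any aryl group on this saturated chain carbon gives a measurable value in this assay.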